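Replacing a hydroxymethyl piperidine with a difluoropiperidine

This account rests on a few compounds, and the source may have more. Where it says the series, first, only, none or still open, it means among the compounds named here.

Of the compounds shown here, three built on the same core have been tested in a functional assay on HEK293 cells for antagonist activity at prostaglandin E2 receptor EP4 subtype (Homo sapiens), read by HTRF and cAMP accumulation, with a stated time of 20 min; on this read-out higher numbers stand for weaker inhibition and lower numbers for stronger inhibition. Compound 1 `Cc1ccc(N2CCCC(CO)C2)nc1C(=O)Nc1c(C)ccc(C(=O)O)c1C` gives 14.2 nM. For the measured compounds named here, compound 2 `Cc1ccc(N2CCC(C)(O)CC2)nc1C(=O)Nc1c(C)ccc(C(=O)O)c1C` gives 87.9 nM, and the only structural step between them produced a 6.2-fold higher number from compound 1 to compound 2 (0.79 log units; beyond the scatter). Compound 3 `Cc1ccc(N2CCCC(CO)C2)nc1C(=O)Nc1c(C)cc(C(=O)O)cc1C` gives 16.5 nM; among the three numbers it stands second highest, within the scatter of compound 1 and well apart from compound 2.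

Compound 4 `Cc1ccc(N2CCC(F)(F)CC2)nc1C(=O)Nc1c(C)cc(C(=O)O)cc1C` has not yet been measured. It differs from compound 3 in one place: 4,4-difluoropiperidin-1-yl in place of 3-(hydroxymethyl)piperidin-1-yl on an aromatic carbon. The group that leaves carries 1 hydrogen-bond donor and 2 hydrogen-bond acceptors; the group that enters carries no donor and a single acceptor. Going by the values given here, the one measured step that bears on this is the one from compound 1 to compound 2, where the same hydroxymethyl-bearing ring left and a ring still carrying a hydroxyl group entered, and the number rose by a modest amount. Compound 4 removes the hydroxyl group altogether, so the step from compound 3 to compound 4 in this assay is expected to be a weakening of similar or somewhat larger size, a 9.1-fold higher number from compound 3 to compound 4 (0.96 log units; beyond the scatter). Compound 4 is therefore estimated at 150 nM, with a range from 40 nM to 600 nM.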

Compound 4, half-maximal inhibitory concentration: 1.61 nM
For compound 4 the middle estimate is 93-fold (1.97 log units) above the measured one; measured number outside the range, below it.
By their numbers in this assay, from the lowest: compound 4; then compounds 1 and 3 (each within the scatter of the next); then compound 2.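

In this assay, replacing 3-(hydroxymethyl)piperidin-1-yl with 4,4-difluoropiperidin-1-yl on this aromatic carbon next to the ring nitrogen gives a 10-fold lower number from compound 3 to compound 4 (1.01 log units; beyond the scatter) and shows that a hydroxyl group on the piperidine is not needed for strong inhibition, as the entering ring has no hydrogen-bond donor. For the compounds shown here, the only earlier change at this position, made with the carboxylic acid placed differently on the core, was a 6.2-fold higher number from compound 1 to compound 2 (0.79 log units; beyond the scatter) and went in the opposite direction, so swapping the saturated ring here can move the number either way and by a wide margin. No measurement shown accounts for the size or direction of the new step.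

The compounds shown leave open whether the result depends on the two fluorine atoms or on the loss of the hydroxymethyl group, a question that a plain piperidine ring at the same position would help to separate. They also leave open whether 4,4-difluoropiperidin-1-yl would have the same effect with the carboxylic acid placed as in compound 1.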